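The compounds below may be only part of what the source reports. "The series", "measured", "known", "first", "only" and "open" are said of these compounds alone.

Measured compounds:
compound 1, `CC(O)(CSc1ccccc1C(F)(F)F)C(=O)Nc1ccc(S(F)(F)(F)(F)F)cc1`, gives 15800 nM in a functional assay on DU-145 cells (Homo sapiens) for antiproliferative activity, read by propidium iodide staining, with a stated time of 96 h; on this read-out higher numbers stand for weaker inhibition and lower numbers for stronger inhibition;
compound 2, `CC(O)(CSc1ccccc1OC(F)(F)F)C(=O)Nc1ccc(S(F)(F)(F)(F)F)cc1`, gives 29000 nM;
compound 3, `CC(O)(COc1cccc(C(F)(F)F)c1)C(=O)Nc1ccc(S(F)(F)(F)(F)F)cc1`, gives 21900 nM.

Compound 1 and compound 2 differ only by trifluoromethoxy in place of trifluoromethyl on an aromatic carbon, and this change brought a 1.8-fold higher number from compound 1 to compound 2 (0.26 log units; within the scatter). Compound 3 has a different core from compound 1; the difference between the two cores is not broken down here. Compound 4, `CC(O)(COc1cccc(OC(F)(F)F)c1)C(=O)Nc1ccc(S(F)(F)(F)(F)F)cc1`, is not yet measured; it differs from compound 3 by trifluoromethoxy in place of trifluoromethyl on an aromatic carbon. Among the compounds with values here, this is the same kind of change as the one from compound 1 to compound 2, but not the same: there the entering group stood ortho to a large group, here it stands meta to a large group. Since the earlier step stayed within the scatter, a similarly small step is expected for compound 4, giving an estimated 1.5-fold higher number from compound 3 to compound 4 (0.18 log units; within the scatter) and an expected value of 33000 nM, likely between 12000 nM and 90000 nM.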

Compound 4, half-maximal inhibitory concentration: 18400 nM
Compound 4: middle estimate off by 1.8-fold (0.25 log units), on the high side; measured number inside the range.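

Putting trifluoromethoxy in place of trifluoromethyl gave a 1.2-fold lower number from compound 3 to compound 4 (0.08 log units; within the scatter) in this assay. Set beside the earlier step on the other core, this result shows no real difference in how the change behaves on the two cores: the same change on two cores in this assay, a 1.8-fold higher number (0.26 log units; within the scatter) from compound 1 to compound 2 and a 1.2-fold lower number (0.08 log units; within the scatter) from compound 3 to compound 4, 2.2-fold (0.34 log units) apart, within the scatter of two such steps. The swap therefore stayed small on both cores, but neither step can be told apart from scatter, so this pair cannot show that a clear effect would carry from one core to another, and two cores say nothing about any further core.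

The compounds shown leave open whether a different group on the same aromatic ring, such as an amine, a carboxylic acid or a nitrile, would move the number beyond the scatter.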